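Swapping a Small Ring for a Trimethoxyphenyl: Cytotoxicity Outlook

The source may report more compounds than this note shows. Statements on the series, on what has been measured and on what is new or still open speak of the compounds shown alone.

Compound 1 `Cc1ccc(CNC(=O)c2nc(C(C)(C)NC(=O)OCc3ccccc3)nc(O)c2O)cc1` gives 234000 nM.
Compound 2 `COCCNC(=O)c1nc(C(C)(C)NC(=O)OCc2ccccc2)nc(O)c1O` gives 348000 nM.
Compound 3 `CC(C)(NC(=O)OCc1ccccc1)c1nc(O)c(O)c(C(=O)NCC2CC2)n1` gives 204000 nM.

In an ADME assay on C8166 cells (Homo sapiens) for cytotoxicity, read by MTT assay, with a stated time of 3 days (a higher number here means that more compound is tolerated, a lower number that less compound is tolerated), the three numbers all lie within the usual scatter of each other: the step of a 1.1-fold lower number from compound 1 to compound 3 (0.06 log units; within the scatter) and the step of a 1.7-fold lower number from compound 2 to compound 3 (0.23 log units; within the scatter) are both small, so compound 3 stands alongside the other two rather than apart from them. Compound 4 `COc1cc(CNC(=O)c2nc(C(C)(C)NC(=O)OCc3ccccc3)nc(O)c2O)cc(OC)c1OC` differs from compound 3 in one place: 3,4,5-trimethoxyphenyl in place of cyclopropyl on a saturated chain carbon bound to an amide-type nitrogen. The measured steps that bear on this change all alter the same carbon, namely a 1.5-fold higher number from compound 1 to compound 2 (0.17 log units; within the scatter), a 1.1-fold lower number from compound 1 to compound 3 (0.06 log units; within the scatter) and a 1.7-fold lower number from compound 2 to compound 3 (0.23 log units; within the scatter), and none of them moved this assay beyond the scatter, even where 4-methylphenyl was exchanged for cyclopropyl. No step beyond the scatter is therefore expected for compound 4, a 1.1-fold higher number from compound 3 to compound 4 (0.05 log units; within the scatter). Compound 4 is estimated to give 230000 nM, with a range from 100000 nM to 500000 nM.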

Compound 4, half-maximal cytotoxic concentration: 110000 nM
Estimate against measurement, compound 4: 2.1-fold (0.32 log units) above; the measured number falls inside the stated range.
By their numbers in this assay, from the lowest: compounds 4, 3, 1 and 2 (each within the scatter of the next, the first and the last beyond it).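

Going by these compounds alone, at this carbon, the earlier swaps all stayed within the scatter in this assay, and 3,4,5-trimethoxyphenyl brings the first steps beyond it, both modest: a 3.2-fold lower number from compound 2 to compound 4 (0.50 log units; beyond the scatter) and a 2.1-fold lower number from compound 1 to compound 4 (0.33 log units; beyond the scatter). Against cyclopropyl it does not clear the scatter, with a 1.9-fold lower number from compound 3 to compound 4 (0.27 log units; within the scatter). So less compound is tolerated with this group than with methoxymethyl or 4-methylphenyl.

On these data alone, whether an amine or a carboxylic acid on this carbon would shift the number remains open. The reason for the shift is also open, as nothing measured here speaks to it.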